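A few compounds are considered here, and "the series" means these few. Any claim that something is new, unique, unknown or untested is made for them only; others in the source may bear on it.

Measured compounds:
Compound 1, `COc1ccc(NC(=O)c2cccc(/C=C3\CC(=O)N(c4ccccc4)C3=O)c2)cc1`: in an ADME assay on NCM460 cells (Homo sapiens) for cytotoxicity, read by MTT assay, with a stated time of 72 h (on this read-out higher numbers stand for weaker inhibition and lower numbers for stronger inhibition), compound 1 gives > 100000 nM, which is a limit of the assay rather than a number.
Compound 2, `Cc1ccc(N2C(=O)C/C(=C\c3cccc(C(=O)Nc4ccc(Cl)cc4)c3)C2=O)cc1`: in this assay compound 2 gives > 100000 nM, likewise a limit.

Compound 2 thus stands at the limit of > 100000 nM in this assay, at which 2 of the 2 values shown sit, and no number separates it from compound 1. Compound 3, `COc1ccc(NC(=O)c2cccc(/C=C3\CC(=O)N(c4ccc(C)cc4)C3=O)c2)cc1`, differs from compound 2 by methoxy in place of chloro on an aromatic carbon. For the measured compounds named here, no step between measured compounds is available. The expected step that the limit leaves unreadable from compound 2 to compound 3 is none beyond the scatter, with a limit again the most likely report. Compound 3 is estimated at 150000 nM, within 60000 nM to 400000 nM.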

Compound 3, half-maximal inhibitory concentration: > 100000 nM
Compound 3: only a limit was reported; the forecaster's own chance of this, stated with the estimate: 85%; the middle value is on the limit's open side.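

No step can be read between compound 3 and compound 1 or compound 2, because all three give only a limit: the limit of > 100000 nM in this assay, at which 3 of the 3 values shown sit.

The compounds shown leave open whether any change on the shared core gives a number rather than a limit.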